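The compounds below may be only part of what the source reports. "The series", "measured", "known", "first", "only" and "open" are said of these compounds alone.

Among the measured compounds shown here, in a functional assay on A549 cells (Homo sapiens) for cytotoxicity, read by MTT assay, with a stated time of 72 h (on this read-out lower numbers stand for stronger inhibition and higher numbers for weaker inhibition), three compounds have numbers so far. Compound 1 (`Cn1ccc2c(Oc3ccc(NC(=O)c4cc5cccnc5n(-c5ccc(Br)cc5)c4=O)cc3)ncnc21`) stands at 52200 nM and compound 2 (`Cn1ccc2c(Oc3ccc(NC(=O)c4cc5cccnc5n(-c5ccccc5)c4=O)cc3F)ncnc21`) stands at 63200 nM. Compound 3 (`Cn1ccc2c(Oc3ccc(NC(=O)c4cc5cccnc5n(-c5ccc(F)cc5)c4=O)cc3F)ncnc21`) reads 7320 nM and so holds the lowest of the three numbers, with both others higher by more than the scatter.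

Compound 4 (`Cn1ccc2c(Oc3ccc(NC(=O)c4cc5cccnc5n(-c5ccc(Br)cc5)c4=O)cc3F)ncnc21`) departs from compound 3 by a single swap (bromo in place of fluoro on an aromatic carbon) in which 4-fluorophenyl becomes 4-bromophenyl. For the measured compounds named here, one measured step bears on this group directly: an 8.6-fold lower number from compound 2 to compound 3 (0.94 log units; beyond the scatter) when fluoro takes the place of hydrogen on that same ring. Going by the values given here, that step says nothing about bromo, and no measured pair compares bromo with fluoro directly. A second clue is indirect. Compounds 3 and 4 share a fluoro on the core that is absent from compound 1, which bears the same 4-bromophenyl group and reads 52200 nM as its number.

Part of the low number of compound 3 is therefore expected to be lost, by an amount no larger than the measured fluoro step. The estimated change is a 2.5-fold higher number from compound 3 to compound 4 (0.39 log units; beyond the scatter) toward weaker inhibition. For compound 4 the estimate is 18000 nM (expected range 5500 nM to 60000 nM).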

Compound 4, half-maximal inhibitory concentration: 42200 nM
Compound 4: middle estimate off by 2.3-fold (0.37 log units), on the low side, and the stated range covers the measured number.
By their numbers in this assay, from the lowest: compound 3; then compounds 4, 1 and 2 (each within the scatter of the next).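

In this assay, the low number of compound 3 belongs to fluoro specifically and not to any halogen on this ring: bromo does not keep it (a 5.8-fold higher number from compound 3 to compound 4 (0.76 log units; beyond the scatter)), and bromo in place of hydrogen on the same ring gives no change that can be separated from the scatter (a 1.5-fold lower number from compound 2 to compound 4 (0.18 log units; within the scatter)). The fluoro on the shared core adds nothing that can be read when the ring carries 4-bromophenyl (a 1.2-fold lower number from compound 1 to compound 4 (0.09 log units; within the scatter)), so compounds 1, 2 and 4 stay together while compound 3 stands alone. Swapping hydrogen for fluoro therefore does not carry the same weight in every setting: the same change on two cores in this assay, an 8.6-fold lower number (0.94 log units; beyond the scatter) from compound 2 to compound 3 and a 1.2-fold lower number (0.09 log units; within the scatter) from compound 1 to compound 4, 7.0-fold (0.84 log units) apart, beyond the scatter of two such steps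

The compounds shown place only hydrogen, fluoro and bromo on this ring, so it remains open whether chloro, methyl, methoxy or a nitrile at the same place would behave like fluoro or like bromo. Among the compounds shown here, no compound pairs 4-fluorophenyl with a core lacking its fluoro, which leaves open whether the low number of compound 3 needs both fluoro groups together.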